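A few compounds are considered here, and "the series" means these few. Any claim that something is new, unique, unknown or untested is made for them only; others in the source may bear on it.

Compound 1, `CN(CC(=O)N1CCN(c2ccc(F)cc2)CC1)C(=O)c1ccc(S(C)(=O)=O)c([N+](=O)[O-])c1`: in an assay on isolated protein for inhibition of vitamin D3 receptor (Homo sapiens), read by fluorescence polarization (on this read-out lower numbers stand for stronger inhibition and higher numbers for weaker inhibition), compound 1 gives > 60000 nM, which is a limit of the assay rather than a number.
Compound 2, `CS(=O)(=O)c1ccc(C(=O)NCC(=O)N2CCCCC2)cc1[N+](=O)[O-]`: in this assay compound 2 gives > 60000 nM, again a limit rather than a number.

Compound 2 thus stands at the reporting limit of this assay, and so does everything else measured here: the limit of > 60000 nM in this assay, at which 2 of the 2 values shown sit. Compound 3, `CN1CCN(C(=O)CNC(=O)c2ccc(S(C)(=O)=O)c([N+](=O)[O-])c2)CC1`, has not yet been measured. It differs from compound 2 in one place: 4-methylpiperazin-1-yl in place of piperidin-1-yl on a carbonyl carbon. Among the compounds with values here, no step between two measured compounds is known, so the size of this change in this assay cannot be read from the data. With both measured values sitting at the limit, there is no ground to expect movement beyond the usual scatter in either direction, and compound 3 is expected most likely to return the same limit. The estimate for compound 3 in this assay is 100000 nM, with a range from 30000 nM to 300000 nM. This estimate is expected to mean a step that the limit leaves unreadable from compound 2 to compound 3.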

Compound 3, half-maximal inhibitory concentration: > 60000 nM
Compound 3: no number, only a limit (the forecaster's own chance of this, stated with the estimate: 85%); the middle value does not contradict the limit.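

Compound 2 and compound 3 both give only a limit in this assay, so no step can be read for placing 4-methylpiperazin-1-yl where piperidin-1-yl stood: the limit of > 60000 nM in this assay, at which 3 of the 3 values shown sit.

The compounds shown leave open which change, if any, would give a true number in this assay.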